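The source may report more compounds than this note shows. Statements on the series, on what has been measured and on what is new or still open speak of the compounds shown alone.

Compound 1 `N#Cc1c(F)c(F)c2nc(N)nc(N)c2c1F` and compound 2 `N#Cc1c(Nc2ccccc2)c(F)c2nc(N)nc(N)c2c1F` share their core with compound 3 `N#Cc1c(NCc2ccccc2)c(Cl)c2nc(N)nc(N)c2c1F`. In a functional assay on A549 cells (Homo sapiens) for cytotoxicity, read by MTT assay (on this read-out higher numbers stand for weaker inhibition and lower numbers for stronger inhibition), compound 1 gives > 1000 ug/mL, a limit of the assay. Compound 2 gives > 1000 ug/mL in this assay, again a limit. The step that the two limits leave unreadable from compound 1 to compound 2 thus cannot be read, and the limit of > 1000 ug/mL in this assay, at which 2 of the 3 values shown sit, marks where both of those values sit. For the measured compounds named here, compound 3 gives 34.1 ug/mL in this assay, the only number among the three. Compound 4 `N#Cc1c(NCc2ccccc2)c(F)c2nc(N)nc(N)c2c1F` differs from compound 3 by fluoro in place of chloro on an aromatic carbon. No readable measured step bears on this change, so the expected step of a 1.5-fold higher number from compound 3 to compound 4 (0.17 log units; within the scatter) in this assay is small. Compound 4 is expected to give about 50 ug/mL, between 15 ug/mL and 180 ug/mL.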

Compound 4, half-maximal inhibitory concentration: > 1000 ug/mL
Compound 4 was reported as a limit; the forecaster's own chance of this, stated with the estimate: 15%; middle value at least 20-fold (1.30 log units) away from the limit.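

In this assay, for the compounds shown here, this carbon ortho to a benzylamino group proves sensitive to the halogen: with the benzylamino group kept, fluoro in place of chloro gives an at least 29-fold higher number from compound 3 to compound 4 (1.46 log units; beyond the scatter), so the only measurable value shown depends on chloro here. The steps joining compound 4 to compound 1 and compound 2 cannot be read. Compound 4 is thus also a limit of the assay: the limit of > 1000 ug/mL in this assay, at which 3 of the 4 values shown sit.

From the compounds shown here alone, whether bromo, methyl or methoxy at this carbon would also give a measurable value stays open. So does whether chloro would do so with the anilino group of compound 2.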